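The source may hold more compounds than are shown below. What is called first, only, known or untested is meant among the compounds shown, and "the series" means these compounds.

The series shares one core, seen in compound 1, `O=C(Nc1cccc(CNc2nccnc2Cl)c1)Nc1ccccc1Cl`, which in a functional assay on MGC-803 cells (Homo sapiens) for antiproliferative activity, read by MTT assay, with a stated time of 48 h (on this read-out lower numbers stand for stronger inhibition and higher numbers for weaker inhibition), gives 7130 nM. Compound 2, `Cc1ccc(NC(=O)Nc2cccc(CNc3nccnc3Cl)c2)cc1Cl`, gives 17500 nM in this assay, and compound 3, `O=C(Nc1cccc(CNc2nccnc2Cl)c1)Nc1ccc(Cl)cc1Br`, gives 7480 nM. Among the three numbers compound 3 stands second highest; its nearest neighbour is compound 1, with the difference a 1.0-fold higher number from compound 1 to compound 3 (0.02 log units; within the scatter), while compound 2 lies further off, with a 2.3-fold lower number from compound 2 to compound 3 (0.37 log units; beyond the scatter).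

Compound 4, `Cc1ccccc1NC(=O)Nc1cccc(CNc2nccnc2Cl)c1`, has not yet been measured. It differs from compound 3 in one place: 2-methylphenyl in place of 2-bromo-4-chlorophenyl on an amide-type nitrogen. Among the compounds with values here, two measured steps bear on this exchange of aryl groups on the amide-type nitrogen. The first moved the number only slightly, a 1.0-fold higher number from compound 1 to compound 3 (0.02 log units; within the scatter), whereas the second, a 2.5-fold higher number from compound 1 to compound 2 (0.39 log units; beyond the scatter), showed a modest weakening when 3-chloro-4-methylphenyl took the place of 2-chlorophenyl. Compound 4 carries 2-methylphenyl, which in its substitution resembles the 2-chlorophenyl of compound 1 more than the 3-chloro-4-methylphenyl of compound 2, so a step of no more than modest size is expected in this assay, a 1.2-fold higher number from compound 3 to compound 4 (0.08 log units; within the scatter), with no confident direction. Compound 4 is therefore estimated at 9000 nM, within a range from 4000 nM to 25000 nM.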

Compound 4, half-maximal inhibitory concentration: 14000 nM
Compound 4: middle estimate off by 1.6-fold (0.19 log units), on the low side; low and high end bracket the measured number.
By their numbers in this assay, from the lowest: compounds 1, 3, 4 and 2 (each within the scatter of the next, the first and the last beyond it).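

In this assay, the 2-methylphenyl group on the amide-type nitrogen cannot be told apart from any of the other three aryl groups, since a 2.0-fold higher number from compound 1 to compound 4 (0.29 log units; within the scatter) and a 1.9-fold higher number from compound 3 to compound 4 (0.27 log units; within the scatter) and also a 1.3-fold lower number from compound 2 to compound 4 (0.10 log units; within the scatter) all lie within the scatter. The earlier compounds shown here had suggested a division at this position, with a 2.5-fold higher number from compound 1 to compound 2 (0.39 log units; beyond the scatter) beyond the scatter, but compound 4 lies within the scatter of both compound 1 and compound 2, so the four aryl groups do not fall into two separate sets. Within the data shown here, the single exchange of methyl in place of chloro on an aromatic carbon, seen between compound 1 and compound 4, likewise gives no step that stands clear of the scatter, and no supporting measurement is available to account for any of these numbers.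

The aryl groups shown carry only chloro, bromo and methyl, so what a methoxy group, an amine or a carboxylic acid on that ring would do remains open. Also open, as far as these compounds go, is whether the aromatic ring on the amide-type nitrogen could give way to a saturated cyclohexyl ring or a longer alkyl chain.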